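Methyl to 3-Fluorophenyl on the Sulfonyl Sulfur

The source may hold more compounds than are shown below. What is called first, only, known or untested is meant among the compounds shown, and "the series" means these compounds.

Measured compounds in an assay on cells for inhibition of HSP60/HSP10 (Homo sapiens), with a stated time of 60 min; a lower number here means a stronger inhibitor, a higher number a weaker inhibitor:
compound 1 `O=S(=O)(Nc1ccc2oc(-c3ccccc3)nc2c1)c1ccc(O)cc1` gives 88000 nM.
compound 2 `COc1cccc(S(=O)(=O)Nc2ccc3oc(-c4ccccc4)nc3c2)c1` gives > 100000 nM, which is a limit of the assay.
compound 3 `CS(=O)(=O)Nc1ccc2oc(-c3ccccc3)nc2c1` gives > 100000 nM, also a limit of the assay.

Compound 3 thus stands at the limit of > 100000 nM in this assay, at which 2 of the 3 values shown sit, and no number is known for it. Compound 4 `O=S(=O)(Nc1ccc2oc(-c3ccccc3)nc2c1)c1cccc(F)c1` differs from it by 3-fluorophenyl in place of methyl on a sulfonyl sulfur. The measured steps bear on this only loosely: an at least 1.1-fold higher number from compound 1 to compound 3 (0.05 log units; that floor lies within the scatter) and an at least 1.1-fold higher number from compound 1 to compound 2 (0.05 log units; that floor lies within the scatter) both run from compound 1 up to the limit, and a step that the two limits leave unreadable from compound 2 to compound 3 cannot be read. The changes on the sulfonyl sulfur seen so far have moved no value beyond the scatter, so a step that the limit leaves unreadable from compound 3 to compound 4 is expected to be no larger than the scatter. Compound 4 is estimated at 120000 nM, between 50000 nM and 300000 nM.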

Compound 4, half-maximal inhibitory concentration: > 100000 nM
Compound 4 was reported as a limit; the forecaster's own chance of this, stated with the estimate: 60%; the middle value lies beyond the limit too.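

Putting 3-fluorophenyl in place of 4-hydroxyphenyl on the sulfonyl sulfur gives an at least 1.1-fold higher number from compound 1 to compound 4 (0.05 log units; that floor lies within the scatter), so this change, like the earlier ones at this position, shows nothing beyond the scatter. The steps to compound 4 from compound 3 and from compound 2 cannot be read. Compound 4, with its 3-fluorophenyl, also sits at a limit of the assay: the limit of > 100000 nM in this assay, at which 3 of the 4 values shown sit.

The compounds shown leave open whether an amine or a carboxylic acid on the phenyl ring at the sulfonyl sulfur would give a value inside the assay's range. They also leave open whether any change on the shared core would do so.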